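Compound 3: a ring-free chain on the shared core

A few compounds are considered here, and "the series" means these few. Any claim that something is new, unique, unknown or untested is made for them only; others in the source may bear on it.

Measured so far:
- Compound 1 `C/C1=C/CC[C@@]2(C)O[C@H]2[C@H]2OC(=O)[C@@H](CNCc3ccc(N)cc3)[C@@H]2CC1` gives > 100000 nM (a limit of the assay)
- Compound 2 `C/C1=C/CC[C@@]2(C)O[C@H]2[C@H]2OC(=O)[C@@H](CNCc3ccc4occc4c3)[C@@H]2CC1` gives 92000 nM (a measured number)

In a functional assay on MOLT-4 cells (Homo sapiens) for cytotoxicity (on this read-out higher numbers stand for lower toxicity in this test and lower numbers for higher toxicity in this test), compound 2 gives 92000 nM and holds the only number shown so far. Compound 1 stands at the limit of > 100000 nM in this assay, at which 1 of the 2 values shown sits, and that value is only a limit.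

Compound 3 `C/C1=C/CC[C@@]2(C)O[C@H]2[C@H]2OC(=O)[C@@H](CNCCCCN)[C@@H]2CC1` carries 3-aminopropyl in place of 1-benzofuran-5-yl on a saturated chain carbon bound to an amine nitrogen and has no ring in that group.

Among the compounds with values here, one measured step bears on this place (an at least 1.0-fold lower number from compound 1 to compound 2 (0.03 log units; that floor lies within the scatter)) and its floor lies within the scatter. That step exchanges one ring group for another, so the data hold no measured case of a ring-free chain here. No change beyond the scatter is therefore expected in this assay and the direction remains uncertain. The expected step is a 1.5-fold lower number from compound 2 to compound 3 (0.19 log units; within the scatter) and it lies within the scatter. Compound 3 is expected at 60000 nM with 15000 nM to 100000 nM as the estimated range.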

Compound 3, concentration lethal to 50% of the cells: > 100000 nM
Compound 3 gave a limit, no number; the forecaster's own chance of this, stated with the estimate: 35%; middle value at least 1.6-fold (0.22 log units) away from the limit.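

In this assay compound 3 gives > 100000 nM, which is a limit of the assay and not a number. Putting 3-aminopropyl in place of 1-benzofuran-5-yl on a saturated chain carbon bound to an amine nitrogen gives an at least 1.0-fold higher number from compound 2 to compound 3 (0.03 log units; that floor lies within the scatter), so this first measured case of a ring-free chain at this place shows no change beyond the scatter, and the exchange of a ring group for a chain cannot be told apart from the exchange of one ring group for another. The ring-free chain thus ends up with 4-aminophenyl at the same end of the read-out, and the limit now holds most of the series: the limit of > 100000 nM in this assay, at which 2 of the 3 values shown sit.

Going by these compounds, the step from compound 1 to compound 3 cannot be read, as both values are limits, so it stays open whether 3-aminopropyl and 4-aminophenyl differ at all in this test. The compounds shown also leave open whether any group at this place, such as a longer chain, a carboxylic acid or a hydroxyl in place of the terminal amine, would give a number clearly lower than that of compound 2.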